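The source may hold more compounds than are shown below. What is called first, only, known or untested is meant among the compounds shown, and "the series" means these compounds.

Values in an ADME assay on WI-38 cells (Homo sapiens) for cytotoxicity, read by MTT assay, with a stated time of 72 h; on this read-out lower numbers stand for stronger inhibition and higher numbers for weaker inhibition:
- Compound 1 `O=C(CCc1cccc2c1B(O)OC2)Nc1ccc(Cl)cc1`: > 100000 nM, a limit
- Compound 2 `Cc1ccc(NC(=O)CCc2cccc3c2B(O)OC3)cc1`: > 100000 nM, a limit
- Compound 3 `CC(C)(C)OC(=O)NCc1ccc(NC(=O)CCc2cccc3c2B(O)OC3)cc1`: 4800 nM

Only compound 3 has an actual number, 4800 nM, in this assay. The rest of the picture is the limit of > 100000 nM in this assay, at which 2 of the 3 values shown sit.

The next compound is compound 4 `O=C(CCc1cccc2c1B(O)OC2)Nc1ccc([N+](=O)[O-])cc1`. It has nitro in place of ((tert-butoxycarbonyl)amino)methyl on an aromatic carbon. Among the measured compounds shown here, the group that leaves is the one feature that sets compound 3 apart from the other two.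

For the measured compounds named here, two measured steps bear on this change, and both are large. The first is an at least 20-fold lower number from compound 1 to compound 3 (1.31 log units; beyond the scatter). The second is an at least 20-fold lower number from compound 2 to compound 3 (1.31 log units; beyond the scatter). Between the two compounds lacking that group there is only a step that the two limits leave unreadable from compound 1 to compound 2. Removing the group should therefore reverse much of the drop seen in those two steps, though nitro itself has not yet been measured on this core. The expected change is a large one towards weaker inhibition, estimated as a 15-fold higher number from compound 3 to compound 4 (1.16 log units; beyond the scatter). The assay may well report only a limit here. For compound 4 the estimated value is 70000 nM, with an expected range from 15000 nM to 150000 nM.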

Compound 4, half-maximal inhibitory concentration: > 100000 nM
Compound 4 ended at the assay's limit (the forecaster's own chance of this, stated with the estimate: 60%); middle value at least 1.4-fold (0.15 log units) away from the limit.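

In this assay, replacing the ((tert-butoxycarbonyl)amino)methyl group with nitro gives an at least 20-fold higher number from compound 3 to compound 4 (1.31 log units; beyond the scatter), a change that is well beyond the usual scatter. Compound 4 therefore joins compound 1 and compound 2, and among the four groups shown on this aromatic carbon, only the one in compound 3 gives a value that is an actual number rather than a limit: the limit of > 100000 nM in this assay, at which 3 of the 4 values shown sit. The steps among compound 1, compound 2 and compound 4 cannot be read, so chloro, methyl and nitro cannot be ranked against one another, but three different groups now share that limit where earlier only two did.

The compounds shown leave open which part of the ((tert-butoxycarbonyl)amino)methyl group matters, and a plain aminomethyl group at this position would separate the effect of the tert-butoxycarbonyl part from that of the rest. As far as these compounds go, it also remains open whether other groups on this carbon, such as a carboxylic acid or a longer chain carrying an amide, would give a measurable value in this assay as compound 3 does.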